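Sulfonyl aryl swap on a shared core

The source may hold more compounds than are shown below. What is called first, only, known or untested is meant among the compounds shown, and "the series" means these compounds.

Compound 3 `CCc1ccc(S(=O)(=O)Nc2ccc3oc(-c4ccccc4)nc3c2)cc1` is one of three measured compounds on a shared core. In an assay on isolated protein for inhibition of malate dehydrogenase, mitochondrial (Sus scrofa), with stated times of 45 min and 30 min (on this read-out lower numbers stand for stronger inhibition and higher numbers for weaker inhibition), compound 3 gives > 63000 nM, which is a limit of the assay and not a number. Compound 1 `Cc1ccccc1S(=O)(=O)Nc1ccc2oc(-c3ccccc3)nc2c1` gives in this assay > 63000 nM, also a limit. Compound 2 `Cc1cccc(S(=O)(=O)Nc2ccc3oc(-c4ccccc4)nc3c2)c1` gives in this assay > 63000 nM, again a limit. Compound 4 `O=S(=O)(Nc1ccc2oc(-c3ccccc3)nc2c1)c1cccc(Cl)c1` has not been measured; it differs from compound 3 by 3-chlorophenyl in place of 4-ethylphenyl on a sulfonyl sulfur. The steps bearing on this change are a step that the two limits leave unreadable from compound 1 to compound 3, a step that the two limits leave unreadable from compound 2 to compound 3 and a step that the two limits leave unreadable from compound 1 to compound 2, none of them readable since (the limit of > 63000 nM in this assay, at which 3 of the 3 values shown sit). No step beyond the scatter can be expected in either direction. Compound 4 is therefore expected near 80000 nM, within 20000 nM to 300000 nM, an estimated step that the limit leaves unreadable from compound 3 to compound 4 that most likely returns another limit.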

Compound 4, half-maximal inhibitory concentration: > 63000 nM
Compound 4 ended at the assay's limit (the forecaster's own chance of this, stated with the estimate: 80%); the middle value lies beyond the limit too.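

No step can be read between compound 4 and compound 1, compound 2 or compound 3, since each value is a limit and not a number: the limit of > 63000 nM in this assay, at which 4 of the 4 values shown sit. The compounds shown leave open whether any aryl group on the sulfonyl sulfur gives a measurable inhibition.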